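The source may hold more compounds than are shown below. What is called first, only, known or untested is meant among the compounds shown, and "the series" means these compounds.

Measured compounds:
compound 1 `Cc1cc(=O)oc2cc(OCc3nnc(S)s3)ccc12` gives 0.011 nM in an assay for inhibition of Amine oxidase [flavin-containing] A (Bos taurus), read by fluorescence, with a stated time of 30 min; on this read-out higher numbers stand for weaker inhibition and lower numbers for stronger inhibition
compound 2 `Cc1c(C)c2ccc(OCc3nnc(S)s3)cc2oc1=O` gives 0.00637 nM in this assay
compound 3 `Cc1cc(=O)oc2cc(OCC(=O)NNC(=S)Nc3ccc(Cl)cc3)ccc12` gives 0.00701 nM in this assay

Compound 1 and compound 2 share a core and differ by one change, (methyl in place of hydrogen on an aromatic carbon). The step it made is a 1.7-fold lower number from compound 1 to compound 2 (0.24 log units; within the scatter). Compound 3 carries a different core; how it differs from the core of compound 1 is not broken down here. Compound 3 and compound 2 give numbers that lie within the scatter of each other, as do compound 3 and compound 1, so no order among the three is claimed.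

Compound 4 `Cc1c(C)c2ccc(OCC(=O)NNC(=S)Nc3ccc(Cl)cc3)cc2oc1=O` is not yet measured. Within the data shown here, it differs from compound 3 by methyl in place of hydrogen on an aromatic carbon, the same change as the one from compound 1 to compound 2, made at a place described in the same words. On that basis compound 4 is expected to show a step of about a 1.6-fold lower number from compound 3 to compound 4 (0.19 log units; within the scatter), resting on the step of a 1.7-fold lower number from compound 1 to compound 2 (0.24 log units; within the scatter) seen with the shared change. The estimate for compound 4 in this assay is 0.0045 nM, with a range from 0.002 nM to 0.012 nM.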

Compound 4, inhibition constant: 0.00651 nM
For compound 4 the middle estimate is 1.4-fold (0.16 log units) below the measured one, within the range that was stated.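

In this assay, methyl in place of hydrogen on an aromatic carbon gives a 1.1-fold lower number from compound 3 to compound 4 (0.03 log units; within the scatter) on the second core. This step and the earlier one both lie within the scatter, so neither shows a real effect of the methyl on its own core, and two cores cannot show how the change behaves across the wider series. What can be said is limited: on these two cores the change gives steps that cannot be told apart, and the pair offers no sign that the core alters its outcome: the same change on two cores in this assay, a 1.7-fold lower number (0.24 log units; within the scatter) from compound 1 to compound 2 and a 1.1-fold lower number (0.03 log units; within the scatter) from compound 3 to compound 4, 1.6-fold (0.21 log units) apart, within the scatter of two such steps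

Open, from the compounds shown here alone, is whether a longer chain such as ethyl or propyl, or an amine or a carboxylic acid, on that same aromatic carbon would give a step beyond the scatter. Also open, going by these compounds, is whether methyl in place of hydrogen stays this small on cores other than these two.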